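Nitro on the phenyl ring of two pyrazoline cores

The compounds below may be only part of what the source reports. "The series", "measured", "known", "first", "only" and "open" are said of these compounds alone.

Measured compounds:
compound 1, `CC(=O)N1N=C(c2cccc3ccccc23)CC1c1ccccc1`, 8460 nM
compound 2, `CC(=O)N1N=C(c2cccc3ccccc23)CC1c1ccccc1[N+](=O)[O-]`, 3540 nM
compound 3, `O=CCN1N=C(c2ccc3ccccc3c2)CC1c1ccccc1`, 7400 nM

In a functional assay on PC-3 cells (Homo sapiens) for cytotoxicity, read by sulforhodamine B assay, with a stated time of 48 h (a lower number here means a stronger inhibitor, a higher number a weaker inhibitor), compound 1 gives 8460 nM, while compound 2 gives 3540 nM. Compound 2 carries the change (nitro in place of hydrogen on an aromatic carbon), and the step it made is a 2.4-fold lower number from compound 1 to compound 2 (0.38 log units; beyond the scatter).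

Compound 3, `O=CCN1N=C(c2ccc3ccccc3c2)CC1c1ccccc1`, is built from the same atoms as compound 1 joined differently; the difference between the two cores is not broken down here. In this assay compound 3 gives 7400 nM, which lies within the scatter of compound 1 and is a higher number than compound 2.

Compound 4, `O=CCN1N=C(c2ccc3ccccc3c2)CC1c1cccc([N+](=O)[O-])c1`, has not yet been measured. It differs from compound 3 by nitro in place of hydrogen on an aromatic carbon. Among the compounds with values here, this is the same kind of change as the one from compound 1 to compound 2, but the place is not identical: in compound 2 the nitro group sits ortho to a large group, in compound 4 it sits meta to a large group, and the two cores also differ.

Because the step of a 2.4-fold lower number from compound 1 to compound 2 (0.38 log units; beyond the scatter) was modest and the place and core are not the same, only a smaller lowering is expected; the estimated step is a 1.5-fold lower number from compound 3 to compound 4 (0.19 log units; within the scatter). For compound 4 the expected value in this assay is 4800 nM, within a range from 2200 nM to 10500 nM.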

Compound 4, half-maximal inhibitory concentration: 2980 nM
The estimate for compound 4 lay 1.6-fold (0.21 log units) above the measured number, and the stated range covers the measured number.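

In this assay, the change from phenyl to 3-nitrophenyl gave a 2.5-fold lower number from compound 3 to compound 4 (0.40 log units; beyond the scatter), a drop of about the same size as the one seen on the other core. Set side by side, the two steps cannot be told apart, so in this small set the nitro group carried over from one core to the other with its size intact: the same change on two cores in this assay, a 2.4-fold lower number (0.38 log units; beyond the scatter) from compound 1 to compound 2 and a 2.5-fold lower number (0.40 log units; beyond the scatter) from compound 3 to compound 4, 1.0-fold (0.02 log units) apart, within the scatter of two such steps. Within the data shown here, this agreement rests on only two pairs, in one assay, and it does not show that the same step would appear on a further core; the nitro group also sits in a different place in each pair, so the roles of place and core cannot be separated, and the numbers do not say why the value falls.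

The compounds shown leave open whether another group on the same aromatic carbon, such as an amine or a carboxylic acid, would move the number in the same direction as nitro does. Among these compounds, they also leave open what nitro would do at a second place on a single core, since no pair here compares two places while the core stays the same.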